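From Acetyl to Isopropyl: A Flat Series Continues

The source may report more compounds than this note shows. Statements on the series, on what has been measured and on what is new or still open speak of the compounds shown alone.

Of the compounds shown here, three built on one shared core have been measured: compound 1 `O=C1CCC(N2C(=O)c3ccc(Nc4ccccc4)cc3C2=O)C(=O)N1`, compound 2 `O=C1CCC(N2C(=O)c3ccc(Nc4ccc(O)cc4)cc3C2=O)C(=O)N1` and compound 3 `CC(=O)c1ccc(Nc2ccc3c(c2)C(=O)N(C2CCC(=O)NC2=O)C3=O)cc1`. In an assay on FRT-Jurkat cells for inhibition of nuclear factor NF-kappa-B complex (Homo sapiens), read by flow cytometry, with a stated time of 24 h, tested at 10 uM (a lower number here means less inhibition, a higher number more inhibition at the concentration tested (going by the name of the read-out)), compound 1 gives 6%, compound 2 gives 4%, and compound 3 gives -2%. For the measured compounds named here, compound 3 carries the lowest of the three numbers, yet the steps of a number 8 percentage points lower from compound 1 to compound 3 (within the scatter) and a number 6 percentage points lower from compound 2 to compound 3 (within the scatter) both sit within the scatter, as does a number 2 percentage points lower from compound 1 to compound 2 (within the scatter), so the series so far shows no change that can be trusted.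

The next compound, compound 4 `CC(C)c1ccc(Nc2ccc3c(c2)C(=O)N(C2CCC(=O)NC2=O)C3=O)cc1`, differs from compound 3 in one place: isopropyl in place of acetyl on an aromatic carbon. The two steps that introduced acetyl at this position did nothing beyond the scatter, and nothing measured here speaks for a larger effect from exchanging it for isopropyl. For compound 4 in this assay the expected step from compound 3 is therefore a number 5 percentage points higher from compound 3 to compound 4 (within the scatter), that is, none beyond the scatter. Compound 4 is estimated at 3%, with a range from -9% to 15%.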

Compound 4, a percentage reported as inhibition, at one concentration (the size of the read-out at that concentration, not a potency): 11%
Compound 4: the middle estimate sits 8 percentage points below what was measured; measured number inside the range.
By their numbers in this assay, from the lowest: compounds 3, 2, 1 and 4 (each within the scatter of the next, the first and the last beyond it).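

For the compounds shown here, on an aromatic carbon para to a large group, the exchange of acetyl for isopropyl gives (a number 13 percentage points higher from compound 3 to compound 4 (beyond the scatter)) the first step to clear the scatter in this assay and so the first sign that this position can register a change at all. The same group set against the other two substituents gives a number 7 percentage points higher from compound 2 to compound 4 (within the scatter) and a number 5 percentage points higher from compound 1 to compound 4 (within the scatter) as steps that stay small, so the separation holds only against acetyl, not against hydroxy or hydrogen. No evidence at hand explains this step.

From the compounds shown here alone, whether an amine, a carboxylic acid or a longer chain at this position would move the number further remains open. So does whether a tert-butyl or a methoxy group would side with isopropyl or with acetyl.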